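A Methyl in Place of Hydrogen on Compound 2

A few compounds are considered here, and "the series" means these few. Any claim that something is new, unique, unknown or untested is made for them only; others in the source may bear on it.

The two measured compounds share a core built around an alkyne and an amide. Compound 1 `C[C@@H](NC(=O)c1ccc(C#Cc2ccc(F)cc2)cn1)C(C)(C)O` gives a largest response of 38.4% in an ADME assay on HEK293 cells for agonist activity at metabotropic glutamate receptor 5 (Rattus norvegicus), read by fluorescence and calcium flux; a lower number here means a smaller maximal response, a higher number a larger maximal response. Compound 2 `C[C@@H](NC(=O)c1ccc(C#Cc2cccc(F)c2)nc1)C(C)(C)O` gives 26.6% in this assay, the lowest of the two numbers, and its nearest neighbour is compound 1, which stands higher by an amount beyond the usual scatter.

Compound 3 `Cc1nc(C#Cc2cccc(F)c2)ccc1C(=O)N[C@H](C)C(C)(C)O` has not yet been measured. Compared with compound 2 it differs in one place: methyl in place of hydrogen on an aromatic carbon. The change sits on an aromatic carbon of a six-membered aromatic ring with one nitrogen, next to the ring nitrogen.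

Among the measured compounds shown here, no step between measured compounds that differ in one place is available, so there is no comparable pair to rest a direction on. The account therefore expects the step of a number 3.4 percentage points higher from compound 2 to compound 3 (within the scatter) to be small, most likely within the scatter, with no strong lean either way. On that basis compound 3 is estimated to give 30% in this assay, with a range from 14% to 50%.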

Compound 3, largest response reached (reported as efficacy), in percent of the reference or control that the assay uses: 9.2%
For compound 3 the middle estimate is 20.8 percentage points above the measured one; the measured number lies below the stated range.
By their numbers in this assay, from the lowest: compound 3; then compound 2; then compound 1.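

Methyl in place of hydrogen on an aromatic carbon, next to the ring nitrogen, gives a number 17.4 percentage points lower from compound 2 to compound 3 (beyond the scatter) in this assay and so provides the first reading of any single change in this series. The change adds only one heavy atom, a single carbon with no hydrogen-bond donors or acceptors, yet the step lies beyond the usual scatter, so this position is not indifferent to substitution in this assay. The information at hand offers no measurement that would explain the drop in maximal response, and this one step, taken on its own, gives a direction for a single pair and not a rule for the series.

The compounds shown leave open whether the lower response belongs to methyl in particular or would also follow from another group on this carbon, such as ethyl, methoxy, chlorine or an amine. They also leave open whether methyl placed next to the ring nitrogen in the shared core of compound 1 would take the response in the same direction, and by a similar amount.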